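The source may hold more compounds than are shown below. What is called first, only, known or untested is meant among the compounds shown, and "the series" means these compounds.

Compound 1 `O=C(O)c1ccc(NC(=O)[C@H](C2CCCCC2)n2c(-c3ccc(Cl)cc3)nc3cc(F)c(F)cc32)c(C(F)(F)F)c1` gives 59% in a functional assay for agonist activity at Bile acid receptor (Homo sapiens), read by a luciferase reporter; on this read-out lower numbers stand for smaller maximal responses and higher numbers for larger maximal responses; compound 2 `COc1cc(C(=O)O)ccc1NC(=O)[C@H](C1CCCCC1)n1c(-c2ccc(Cl)cc2)nc2cc(F)c(F)cc21` gives 32%.

Compound 2 is the lower of the two measured numbers, standing a number 27 percentage points lower from compound 1 to compound 2 (beyond the scatter). Compound 3 `O=C(O)CCc1ccc(NC(=O)[C@H](C2CCCCC2)n2c(-c3ccc(Cl)cc3)nc3cc(F)c(F)cc32)c(F)c1` differs from compound 2 by a group of 12 heavy atoms (9 carbon, 2 oxygen, 1 fluorine; one six-membered aromatic ring of carbon only) in place of a group of 11 heavy atoms (8 carbon, 3 oxygen; one six-membered aromatic ring of carbon only), on an amide-type nitrogen. For the measured compounds named here, the single measured step, methoxy in place of trifluoromethyl, lowered the efficacy and bears on this change only in part, since the methoxy leaves while the acid is also altered; no measured step covers the remainder. A moderate rise, a number 13 percentage points higher from compound 2 to compound 3 (beyond the scatter), is therefore expected. For compound 3 the estimate in this assay is 45%, expected to fall between 22% and 68%.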

Compound 3, largest response reached (reported as efficacy), in percent of the reference or control that the assay uses: 17%
For compound 3 the middle estimate is 28 percentage points above the measured one, and the stated range ends above it.
By their numbers in this assay, from the lowest: compound 3; then compound 2; then compound 1.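

In this assay, replacing 4-carboxy-2-methoxyphenyl on the amide-type nitrogen gave a number 15 percentage points lower from compound 2 to compound 3 (beyond the scatter), so this larger replacement lowered the response further, which the earlier methoxy step could not show. Unlike that step, it changes the whole group at once, so its fluorine and its altered acid chain cannot be told apart. Nothing shown explains the drop. Still open, as far as these compounds go, is which part of the change carries the drop, and how a trifluoromethyl group on the same chain, a longer chain, or an amine in place of the carboxylic acid would read.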